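Working notes: 2-chlorophenyl to 3-chlorophenyl

A few compounds are considered here, and "the series" means these few. Any claim that something is new, unique, unknown or untested is made for them only; others in the source may bear on it.

- Compound 1 `Cc1cccc(-c2cc(-c3ccoc3)cc(-c3ccc(Cl)s3)n2)c1` gives 23600 nM
- Compound 2 `Clc1ccc(-c2cc(-c3ccoc3)cc(-c3ccccc3Cl)n2)s1` gives 19000 nM

Both values come from a functional assay on HeLa cells (Homo sapiens) for cytotoxicity, read by ELISA, with a stated time of 4 days (a lower number here means a stronger inhibitor, a higher number a weaker inhibitor), and lie within the scatter of each other, so compound 2 stands level with compound 1. Compound 3 `Clc1cccc(-c2cc(-c3ccoc3)cc(-c3ccc(Cl)s3)n2)c1` is still unmeasured. It carries 3-chlorophenyl in place of 2-chlorophenyl on an aromatic carbon, next to the ring nitrogen (3-chlorophenyl in place of 2-chlorophenyl on an aromatic carbon). Within the data shown here, one measured step bears on this change, at the same place: 2-chlorophenyl in place of 3-methylphenyl (a 1.2-fold lower number from compound 1 to compound 2 (0.09 log units; within the scatter)). Among the measured compounds shown here, no measured pair covers this exact change, so that single small step is the only guide. No step beyond the scatter is expected in this assay, and no direction can be favoured (a 1.1-fold higher number from compound 2 to compound 3 (0.02 log units; within the scatter)). For compound 3 the estimated value is 20000 nM (expected range 9000 nM to 45000 nM).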

Compound 3, half-maximal inhibitory concentration: 23700 nM
The estimate for compound 3 lay 1.2-fold (0.07 log units) below the measured number; the range from low to high includes it.
By their numbers in this assay, from the lowest: compounds 2, 1 and 3 (each within the scatter of the next).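

Placing the chlorine as 3-chlorophenyl rather than 2-chlorophenyl, on the aromatic carbon next to the ring nitrogen, gives no step beyond the scatter in this assay (a 1.2-fold higher number from compound 2 to compound 3 (0.10 log units; within the scatter)). The chloro in place of methyl on the same phenyl ring is also within the scatter (a 1.0-fold higher number from compound 1 to compound 3 (0.00 log units; within the scatter)), so among these three compounds neither the site of the chlorine nor the choice between chloro and methyl separates the numbers. No supporting data accompany these results to explain them.

On these data alone, all three compounds carry a substituted phenyl at this place, so it remains open whether an amine, a carboxylic acid or a longer chain there would give a step beyond the scatter. As far as these compounds go, the furan-3-yl and 5-chlorothiophen-2-yl groups are the same throughout, and their contribution also remains open.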